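Fluoro in place of methoxy on compound 1

The source may hold more compounds than are shown below. What is called first, only, known or untested is meant among the compounds shown, and "the series" means these compounds.

- compound 1 `COc1ccc2c(/C=C(\C#N)C(=O)c3c[nH]c4cc(F)ccc34)c[nH]c2c1`: 10300 nM
- compound 2 `COc1ccc2c(/C=C(\C#N)C(=O)c3c[nH]c4cc(OC)ccc34)c[nH]c2c1`: 1900 nM

Both values come from a functional assay on A549 cells (Homo sapiens) for cytotoxicity, read by WST assay, with a stated time of 24 h; on this read-out higher numbers stand for weaker inhibition and lower numbers for stronger inhibition. Of the two, compound 1 carries the higher number, 10300 nM, and so is the weaker inhibitor of the pair. Compound 3 `N#C/C(=C\c1c[nH]c2cc(F)ccc12)C(=O)c1c[nH]c2cc(F)ccc12` has not yet been measured. It departs from compound 1 by one change: fluoro in place of methoxy on an aromatic carbon. Going by the values given here, the only measured step that bears on this is a 5.4-fold lower number from compound 1 to compound 2 (0.73 log units; beyond the scatter), which put methoxy in place of fluoro on an aromatic carbon. That is the same exchange in the opposite direction, but at a different aromatic carbon, so it is only an indirect guide. A modest rise in this assay is therefore expected, probably smaller than that step. The expected change is a 2.4-fold higher number from compound 1 to compound 3 (0.39 log units; beyond the scatter). For compound 3 the estimated value is 25000 nM, with an expected range from 8000 nM to 80000 nM.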

Compound 3, half-maximal inhibitory concentration: > 50000 nM
Compound 3 gave a limit, no number; the forecaster's own chance of this, stated with the estimate: 15%; middle value at least 2.0-fold (0.30 log units) away from the limit.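

In this assay compound 3 gives > 50000 nM, which is a limit of the assay and not a number. Fluoro in place of methoxy at this aromatic carbon still yields a clear step, an at least 4.8-fold higher number from compound 1 to compound 3 (0.68 log units; beyond the scatter), so the choice between the two groups matters here as well as at the aromatic carbon changed in the earlier step, a 5.4-fold lower number from compound 1 to compound 2 (0.73 log units; beyond the scatter). In both steps the compound with methoxy carries the lower number, but the full size of the new step stays unknown: the limit of > 50000 nM in this assay, at which 1 of the 3 values shown sits.

The compounds shown leave open whether a group other than methoxy or fluoro at this aromatic carbon, such as an amine, a hydroxyl or an ethoxy chain, would bring the number lower still. They also leave open whether a carboxylic acid there would be tolerated at all.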